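A few compounds are considered here, and "the series" means these few. Any claim that something is new, unique, unknown or untested is made for them only; others in the source may bear on it.

Three related compounds have numbers in a functional assay on HUVEC cells (Homo sapiens) for inhibition, read by microscopy and crystal violet staining, with a stated time of 20 h; on this read-out higher numbers stand for weaker inhibition and lower numbers for stronger inhibition. Compound 1 (`COc1cc(O)c2c(=O)c(OC)c(-c3ccc4c(c3)OC(c3ccc(O)c(OC)c3)C(CO)O4)oc2c1`) gives 49900 nM, compound 2 (`COc1cc(C2Oc3cc(-c4oc5cc(O)cc(O)c5c(=O)c4OC(=O)c4cc(O)c(O)c(O)c4)ccc3OC2CO)ccc1O`) gives 36800 nM, and compound 3 (`COc1cc(C2Oc3cc(-c4oc5cc(O)cc(O)c5c(=O)c4O)ccc3OC2COC(=O)c2cc(O)c(O)c(O)c2)ccc1O`) gives 11900 nM, the lowest of the three and beyond the scatter of both others. Compound 4 (`COCC1Oc2ccc(-c3oc4cc(O)cc(O)c4c(=O)c3O)cc2OC1c1ccc(O)c(OC)c1`) differs from compound 3 in one place: methyl in place of (3,4,5-trihydroxyphenyl)carbonyl on an oxygen on a saturated carbon. Among the compounds with values here, no measured pair shows this change alone. Compound 1 has no (3,4,5-trihydroxyphenyl)carbonyl group and gives 49900 nM, but compound 2 carries that group in another place and still gives 36800 nM. Weaker inhibition, beyond the scatter, is expected, with an estimated step of a 3.2-fold higher number from compound 3 to compound 4 (0.50 log units; beyond the scatter). Compound 4 is estimated at 38000 nM, with an expected range of 16000 nM to 90000 nM.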

Compound 4, half-maximal inhibitory concentration: 10500 nM
Estimate against measurement, compound 4: 3.6-fold (0.56 log units) above; the whole stated range lies above it.
By their numbers in this assay, from the lowest: compounds 4 and 3 (each within the scatter of the next); then compounds 2 and 1 (each within the scatter of the next).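

In this assay, replacing (3,4,5-trihydroxyphenyl)carbonyl with methyl on an oxygen on a saturated carbon gives a 1.1-fold lower number from compound 3 to compound 4 (0.05 log units; within the scatter). Within the data shown here, this isolates the change for the first time: at this position, a group with an aromatic ring and hydrogen-bond donors and a single methyl cannot be told apart in this read-out. Nothing shown explains why the two compounds read alike. On these data alone, whether an amine or a carboxylic acid in place of the methoxy would read the same remains open. So does whether a longer chain on that oxygen would keep this level of inhibition.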